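This account rests on a few compounds, and the source may have more. Where it says the series, first, only, none or still open, it means among the compounds named here.

Compound 1 `O=C(CCC(=O)OCCCCCCSc1ccc([N+](=O)[O-])c2nonc12)Nc1ccccc1F` gives 9890 nM in an assay on isolated protein for inhibition of glutathione S-transferase P (Homo sapiens), with a stated time of 10 min; on this read-out higher numbers stand for weaker inhibition and lower numbers for stronger inhibition.
Compound 2 `Cc1ccccc1NC(=O)CCC(=O)OCCCCCCSc1ccc([N+](=O)[O-])c2nonc12` gives 4100 nM in this assay.

Compound 2 has the lower of the two numbers in this assay, set apart from compound 1 by the step of a 2.4-fold lower number from compound 1 to compound 2 (0.38 log units; beyond the scatter). Compound 3 `O=C(CCC(=O)OCCCCCCSc1ccc([N+](=O)[O-])c2nonc12)Nc1ccc(Br)cc1` differs from compound 2 by 4-bromophenyl in place of 2-methylphenyl on an amide-type nitrogen. Going by the values given here, the one measured step, a 2.4-fold lower number from compound 1 to compound 2 (0.38 log units; beyond the scatter), exchanges one aryl substituent for another and is modest; no step touches a bromophenyl group. In this assay, among the compounds with values here, compound 3 is therefore expected to land near compound 2, with no step clearly beyond the scatter. The expected step is a 1.2-fold higher number from compound 2 to compound 3 (0.09 log units; within the scatter). Compound 3 is estimated at 5000 nM, range 1800 nM to 14000 nM.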

Compound 3, half-maximal inhibitory concentration: 5090 nM
The estimate for compound 3 lay 1.0-fold (0.01 log units) below the measured number; measured number inside the range.
By their numbers in this assay, from the lowest: compounds 2, 3 and 1 (each within the scatter of the next, the first and the last beyond it).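

The exchange of 2-methylphenyl for 4-bromophenyl on the amide-type nitrogen is a 1.2-fold higher number from compound 2 to compound 3 (0.09 log units; within the scatter), and the exchange of 2-fluorophenyl for 4-bromophenyl at the same place is a 1.9-fold lower number from compound 1 to compound 3 (0.29 log units; within the scatter). In this assay, a bromine-bearing aryl group at this position therefore cannot be told apart from either earlier aryl group, although those two differ from each other. Nothing available explains this result.

As far as these compounds go, whether an amine or a carboxylic acid on this aryl ring would give a step beyond the scatter remains open. So does the effect of a longer chain in the linker.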